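The source may report more compounds than this note shows. Statements on the series, on what has been measured and on what is new or still open speak of the compounds shown alone.

Measured set in an ADME assay on A549 cells (Homo sapiens) for cytotoxicity, with a stated time of 72 h; on this read-out lower numbers stand for stronger inhibition and higher numbers for weaker inhibition:
compound 1 `COc1cc(NC(C)CCCN2C(=O)CN(C(=O)[C@H](N)CC(C)C)C2(C)C)c2ncccc2c1` gives 21200 nM.
compound 2 `COc1cc(NC(C)CCCN2C(=O)CN(C(C)=O)C2(C)C)c2ncccc2c1` gives > 100000 nM, a limit of this assay.
compound 3 `COc1cc(NC(C)CCCN2C(=O)CN(C(=O)CN)C2(C)C)c2ncccc2c1` gives > 100000 nM, a limit of this assay.

Compound 2 thus stands at a limit and carries no number of its own; the same holds for compound 3, as the limit of > 100000 nM in this assay, at which 2 of the 3 values shown sit, shows. The change to compound 4 `COc1cc(N(C(C)=O)C(C)CCCN2C(=O)CN(C(C)=O)C2(C)C)c2ncccc2c1` is acetyl in place of hydrogen on a nitrogen on an aromatic ring. The measured steps all lie elsewhere on the shared core: an at least 4.7-fold higher number from compound 1 to compound 2 (0.67 log units; beyond the scatter) and an at least 4.7-fold higher number from compound 1 to compound 3 (0.67 log units; beyond the scatter) alter the acyl group on the ring nitrogen of the cyclic amide, and a step that the two limits leave unreadable from compound 2 to compound 3. Within the data shown here, none of them touches the nitrogen on the aromatic ring, so no measured step bears on this change. The expected step is a number no higher from compound 2 to compound 4 (the limit leaves the size open), with the value staying at or near the limit. Compound 4 is therefore estimated at 100000 nM, in a range from 40000 nM to 300000 nM.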

Compound 4, half-maximal inhibitory concentration: > 100000 nM
Compound 4: no number, only a limit; the forecaster's own chance of this, stated with the estimate: 75%; the middle value sits exactly at the limit.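

Compound 4 gives > 100000 nM, a limit of the assay. Compound 2 also carries only a limit, so no step can be read from compound 2 to compound 4. The compounds shown leave open what acetyl in place of hydrogen on a nitrogen on an aromatic ring does to the read-out.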